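Shifting the chloro group on the phenyl ring

This account rests on a few compounds, and the source may have more. Where it says the series, first, only, none or still open, it means among the compounds named here.

In a functional assay on EC9706 cells (Homo sapiens) for cytotoxicity, read by MTT assay, with a stated time of 72 h (on this read-out higher numbers stand for weaker inhibition and lower numbers for stronger inhibition), compound 1 `CCOC(=O)c1ccc(NC(=O)CSC(=S)N[C@H]2CCOC2=O)cc1` gives 112000 nM. Compound 2 `O=C(CSC(=S)N[C@H]1CCOC1=O)Nc1ccc(C(=O)/C=C/c2ccccc2)cc1` gives 44900 nM, and compound 3 `O=C(CSC(=S)N[C@H]1CCOC1=O)Nc1ccc(C(=O)/C=C/c2ccccc2Cl)cc1` gives 34100 nM. Compound 3 therefore has the lowest of the three numbers, though it cannot be separated from compound 2 once the usual scatter is considered. Both lie clearly under compound 1: 2-phenylethenyl in place of ethoxy gives a 2.5-fold lower number from compound 1 to compound 2 (0.40 log units; beyond the scatter), and 2-(2-chlorophenyl)ethenyl in place of ethoxy gives a 3.3-fold lower number from compound 1 to compound 3 (0.52 log units; beyond the scatter).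

Compound 4 `O=C(CSC(=S)N[C@H]1CCOC1=O)Nc1ccc(C(=O)/C=C/c2cccc(Cl)c2)cc1` has the same atoms as compound 3, joined differently. It carries 3-chlorophenyl in place of 2-chlorophenyl on a double-bonded chain carbon bound to a double-bonded chain carbon. Within the data shown here, no measured pair shows this exact swap. The closest guide is the addition of the chloro group itself, which gives a 1.3-fold lower number from compound 2 to compound 3 (0.12 log units; within the scatter). The two larger steps replaced the whole ethoxy group, so they say less about this change. With the step to compound 3 that small, no shift beyond the scatter is expected in this assay, in either direction. The expected step is a 1.0-fold higher number from compound 3 to compound 4 (0.01 log units; within the scatter). Compound 4 is estimated at 35000 nM, with an expected range of 17000 nM to 72000 nM.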

Compound 4, half-maximal inhibitory concentration: 32500 nM
Compound 4: the middle estimate sits 1.1-fold (0.03 log units) above what was measured; the range from low to high includes it.
By their numbers in this assay, from the lowest: compounds 4, 3 and 2 (each within the scatter of the next); then compound 1.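

In this assay, moving the chloro group, so that 3-chlorophenyl stands in place of 2-chlorophenyl, gives a 1.0-fold lower number from compound 3 to compound 4 (0.02 log units; within the scatter), which means these two chlorinated rings cannot be told apart here. Adding chloro to the plain phenyl ring as 3-chlorophenyl gives a 1.4-fold lower number from compound 2 to compound 4 (0.14 log units; within the scatter), so this second chlorinated compound also stays within the scatter of the unchlorinated one, and the only step beyond the scatter is still the replacement of ethoxy, here a 3.4-fold lower number from compound 1 to compound 4 (0.54 log units; beyond the scatter). No measurement is available that would explain these results.

On these data alone, it remains open whether any group on this phenyl ring can move the number beyond the scatter, and a methoxy group, an amine or a carboxylic acid in place of the chloro would test this. It is also unknown how much of the step away from ethoxy depends on the 2-phenylethenyl chain itself, which a longer chain or a saturated two-carbon chain at the same place could help to show.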